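The source may report more compounds than this note shows. Statements on the series, on what has been measured and on what is new or still open speak of the compounds shown alone.

Among the measured compounds shown here, compound 1 `COc1ccc(C2SCC(=O)N2n2c(CSc3nnc(-c4ccncc4)o3)nc3ccccc3c2=O)cc1` gives 33.8% in a functional assay on the whole organism (strain Charles-Foster albino) for inhibition, with Rattus norvegicus as the target, read by paw edema, at a dose of 50 mg/kg by the oral route (a lower number here means less inhibition, a higher number more inhibition at the dose given (going by the name of the read-out)), and stands highest of the two numbers measured so far. Its nearest neighbour, compound 2 `O=c1c2cc(Br)ccc2nc(CSc2nnc(-c3ccncc3)o2)n1/N=C/c1ccccc1`, gives 19.4% in this assay, a gap beyond the usual scatter. Compound 3 `O=C1CSC(c2ccc(Cl)cc2)N1n1c(CSc2nnc(-c3ccncc3)o2)nc2ccccc2c1=O` is not yet measured in this assay. For the measured compounds named here, compound 3 differs from compound 1 by chloro in place of methoxy on an aromatic carbon; no measured pair shows this same change. With no such reference, the step of a number 1.8 percentage points lower from compound 1 to compound 3 (within the scatter) is expected to be small, in no particular direction, and within the scatter. Compound 3 is accordingly estimated at 32% in this assay, with a range from 20% to 45%.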

Compound 3, a percentage reported as inhibition, in the whole organism at one dose (the size of the read-out at that dose, not a potency): 34.1%
Beside the measured number, compound 3's estimate is 2.1 percentage points below it; measured number inside the range.
By their numbers in this assay, from the lowest: compound 2; then compounds 1 and 3 (each within the scatter of the next).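

On the six-membered aromatic ring of carbon only, para to a large group, chloro in place of methoxy gives a number 0.3 percentage points higher from compound 1 to compound 3 (within the scatter) in this assay, so 4-methoxyphenyl and 4-chlorophenyl cannot be told apart at this dose. Among the compounds shown here, this one pair is the first reading at this position, and it shows that this exchange leaves the read-out within the scatter. No measurement shown speaks to why the two groups read alike. From the compounds shown here alone, whether an amine, a carboxylic acid or a plain phenyl at this place would read the same stays open. So does whether the match holds at other doses.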